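The compounds below may be only part of what the source reports. "The series", "measured", "known", "first", "only" and "open" are said of these compounds alone.

Measured so far:
compound 1 `N#CCCn1cc(-c2nc(Nc3ccc4c(c3)CCN4S(=O)(=O)C(F)(F)F)ncc2F)cn1` – 0.163 h
compound 2 `N#CCCn1cc(-c2nc(Nc3ccc4c(c3)CCN4S(=O)(=O)c3ccc(C(F)(F)F)cc3)ncc2F)cn1` – 0.153 h
compound 3 `N#CCCn1cc(-c2nc(Nc3ccc4c(ccn4S(=O)(=O)C(F)(F)F)c3)ncc2F)cn1` – 2.03 h

In an ADME assay on microsomes from liver (Homo sapiens) for metabolic stability (a lower number here means that the compound disappears faster, a higher number that the compound lasts longer), compound 1 gives 0.163 h and compound 2 gives 0.153 h. The change between them, (4-(trifluoromethyl)phenyl in place of trifluoromethyl on a sulfonyl sulfur), produced a 1.1-fold lower number from compound 1 to compound 2 (0.03 log units; within the scatter). Compound 3 gives 2.03 h in this assay, the highest of the three; the difference between its core and the core of compound 1 is not broken down here.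

Compound 4 `N#CCCn1cc(-c2nc(Nc3ccc4c(ccn4S(=O)(=O)c4ccc(C(F)(F)F)cc4)c3)ncc2F)cn1` is not yet measured. It differs from compound 3 by 4-(trifluoromethyl)phenyl in place of trifluoromethyl on a sulfonyl sulfur, the same kind of change as from compound 1 to compound 2, though here the sulfonyl sulfur's other neighbour is an aromatic nitrogen rather than a sulfonamide nitrogen in a ring. Because the earlier step of a 1.1-fold lower number from compound 1 to compound 2 (0.03 log units; within the scatter) stayed within the scatter, the step from compound 3 to compound 4 in this assay is expected to be about a 1.1-fold lower number from compound 3 to compound 4 (0.03 log units; within the scatter). Compound 4 is therefore estimated at 1.9 h, between 0.9 h and 4 h.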

Compound 4, half-life: 0.635 h
For compound 4 the middle estimate is 3.0-fold (0.48 log units) above the measured one, outside the stated range (below it).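

In this assay, 4-(trifluoromethyl)phenyl in place of trifluoromethyl on a sulfonyl sulfur whose other neighbour is an aromatic nitrogen gives a 3.2-fold lower number from compound 3 to compound 4 (0.50 log units; beyond the scatter). The change therefore does not carry over at one size between these two cores: the same change on two cores in this assay, a 1.1-fold lower number (0.03 log units; within the scatter) from compound 1 to compound 2 and a 3.2-fold lower number (0.50 log units; beyond the scatter) from compound 3 to compound 4, 3.0-fold (0.48 log units) apart, beyond the scatter of two such steps. With a single pair on each core, this shows that the size of the step differs between the two cores, but not which difference between the cores accounts for it, nor what the step would be on any other core.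

Open, from the compounds shown here alone, is whether a methyl or an unsubstituted phenyl on the sulfonyl sulfur would show the same gap between the two cores.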